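The source may report more compounds than this note shows. Statements on the series, on what has been measured and on what is new or still open speak of the compounds shown alone.

Measured so far in an ADME assay on cells (Homo sapiens) for cytotoxicity, read by resazurin assay, with a stated time of 5 days; on this read-out lower numbers stand for higher toxicity in this test and higher numbers for lower toxicity in this test:
compound 1 `COc1ccc(-c2nc(CNc3cccc(Cl)c3)nc3ccsc23)cn1` gives > 50000 nM, a limit of the assay.
compound 2 `COc1ccc(-c2nc(CSc3cccc(Br)c3)nc3ccsc23)cn1` gives > 50000 nM, a limit of the assay.
compound 3 `O=S(=O)(Cc1nc(-c2cccs2)c2sccc2n1)c1cccc(Cl)c1` gives > 50000 nM, a limit of the assay.

Compound 3 thus stands at the limit of this assay. All three values shown sit at that same limit (the limit of > 50000 nM in this assay, at which 3 of the 3 values shown sit). Among the compounds with values here, the single step between measured compounds, a step that the two limits leave unreadable from compound 1 to compound 2, is unreadable, both of its ends being limits. Within the data shown here, compound 4 `O=S(=O)(Cc1nc(-c2ccncc2)c2sccc2n1)c1cccc(Cl)c1` carries a change for which no measured pair supplies a step: pyridin-4-yl in place of thiophen-2-yl on an aromatic carbon. The numbers shown therefore give no size and no direction for the step in this assay; the expectation is that compound 4 again sits at or beyond the limit. The estimated step is a step that the limit leaves unreadable from compound 3 to compound 4. Compound 4 is expected at 80000 nM, range 30000 nM to 300000 nM, most likely reported only as a limit.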

Compound 4, half-maximal cytotoxic concentration: > 50000 nM
Compound 4: a limit, no number; the forecaster's own chance of this, stated with the estimate: 85%; the middle value lies beyond the limit too.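

Compound 3 and compound 4 both stand only as limits, so no step between them can be read: the limit of > 50000 nM in this assay, at which 4 of the 4 values shown sit.
The compounds shown leave open at what concentration any of them becomes cytotoxic, and whether pyridin-4-yl in place of thiophen-2-yl changes that concentration.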